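The compounds below may be only part of what the source reports. "The series", "measured", "known", "first", "only" and "open" are said of these compounds alone.

The measured compounds are:
compound 1, `Cc1ccc(S/C(=C/c2ccc(Br)cc2)C(=O)c2ccc(Cl)cc2)cc1`, giving 25000 nM;
compound 2, `Cc1ccc(S/C(=C/c2sccc2C)C(=O)c2ccc(Cl)cc2)cc1`, giving 50000 nM;
compound 3, `Cc1ccc(CS/C(=C/c2ccc(Br)cc2)C(=O)c2ccc(Cl)cc2)cc1`, giving 10000 nM.

All three were tested in a functional assay on DU-145 cells (Homo sapiens) for inhibition, read by trypan blue exclusion, with a stated time of 96 h; on this read-out lower numbers stand for stronger inhibition of growth and higher numbers for weaker inhibition of growth. Compound 1 and compound 2 share a core and differ in one place only: 3-methylthiophen-2-yl in place of 4-bromophenyl on a double-bonded chain carbon bound to a double-bonded chain carbon. This change gave a 2.0-fold higher number from compound 1 to compound 2 (0.30 log units; within the scatter). Compound 3 differs from compound 1 at the sulfur: 4-methylbenzyl in place of 4-methylphenyl on a sulfur. That change gave a 2.5-fold lower number from compound 1 to compound 3 (0.40 log units; beyond the scatter), and compound 3 holds the lowest number of the three measured compounds, with compound 1 nearest to it and compound 2 furthest away.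

Compound 4, `Cc1ccc(CS/C(=C/c2sccc2C)C(=O)c2ccc(Cl)cc2)cc1`, has not yet been measured. It differs from compound 3 by 3-methylthiophen-2-yl in place of 4-bromophenyl on a double-bonded chain carbon bound to a double-bonded chain carbon. For the measured compounds named here, this is the same change as the one from compound 1 to compound 2, now made on the core of compound 3 instead of the core of compound 1, and the place is described in the same words in both cases. The step expected onto compound 4 is a 2.0-fold higher number from compound 3 to compound 4 (0.30 log units; within the scatter), which is estimated on the basis that the same change gave a 2.0-fold higher number from compound 1 to compound 2 (0.30 log units; within the scatter), and nothing in the data speaks to whether the sulfur substituent alters its effect. Compound 4 is therefore estimated at 20000 nM in this assay, with an expected range from 8000 nM to 50000 nM.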

Compound 4, concentration for 50% growth inhibition: 10000 nM
For compound 4 the middle estimate is 2.0-fold (0.30 log units) above the measured one; low and high end bracket the measured number.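

In this assay, putting 3-methylthiophen-2-yl in place of 4-bromophenyl on the core bearing 4-methylbenzyl gave no change at the digits printed from compound 3 to compound 4 (within the scatter), and this step agrees with the earlier one on the core bearing 4-methylphenyl: the same change on two cores in this assay, a 2.0-fold higher number (0.30 log units; within the scatter) from compound 1 to compound 2 and no change at the digits printed (within the scatter) from compound 3 to compound 4, 2.0-fold (0.30 log units) apart, within the scatter of two such steps. The change on the sulfur, 4-methylbenzyl in place of 4-methylphenyl, gave a 5.0-fold lower number from compound 2 to compound 4 (0.70 log units; beyond the scatter), and it also agrees with its earlier counterpart on the other core: the same change on two cores in this assay, a 2.5-fold lower number (0.40 log units; beyond the scatter) from compound 1 to compound 3 and a 5.0-fold lower number (0.70 log units; beyond the scatter) from compound 2 to compound 4, 2.0-fold (0.30 log units) apart, within the scatter of two such steps. Each change therefore carried from one core to the other in these four compounds with no difference that can be told from the scatter, but this rests on a single pair of steps per change in one assay, so it neither excludes a small dependence on the core nor shows that the two changes would combine in the same way elsewhere in the series.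

As far as these compounds go, what a carboxylic acid or an amine would do in place of 4-bromophenyl on a double-bonded chain carbon bound to a double-bonded chain carbon remains open, as does a longer chain in place of 4-methylbenzyl on the sulfur. From the compounds shown here alone, it is also open whether either step would keep its size in a read-out other than this assay.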